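Compound 3 and its isopropyl ester in a cytotoxicity assay

The compounds below may be only part of what the source reports. "The series", "measured", "known", "first", "only" and "open" are said of these compounds alone.

Values in an ADME assay on H1-HeLa cells (Homo sapiens) for cytotoxicity, read by MTT assay, with a stated time of 3 days; a higher number here means that more compound is tolerated, a lower number that less compound is tolerated:
- compound 1 `CNC(=O)c1cc(Oc2ccc3c(C)c(C(=O)O)sc3c2)ccn1`: > 100000 nM
- compound 2 `CNC(=O)c1cc(Oc2ccc3c(C)c(C(=O)OC(C)C)[nH]c3c2)ccn1`: 14600 nM
- compound 3 `CNC(=O)c1cc(Oc2ccc3ccc(C(=O)OC)cc3c2)ccn1`: 53500 nM

The entry for compound 1, > 100000 nM, is a limit of the assay and not a number.

Of the two true numbers, compound 3 holds the higher at 53500 nM, while compound 2 lies lower at 14600 nM, a gap beyond the usual scatter. These two compounds differ in their cores as well as their esters, so the gap does not isolate any single change.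

Compound 4 `CNC(=O)c1cc(Oc2ccc3ccc(C(=O)OC(C)C)cc3c2)ccn1` carries isopropyl in place of methyl on an oxygen next to a carbonyl group. Among the compounds with values here, no measured pair shows this change alone. Within the data shown here, the only guide is compound 2, which carries isopropoxycarbonyl on another core and gives 14600 nM. In this assay, a modest step to a lower number is therefore expected, though it may not clear the scatter. The estimated change is a 1.7-fold lower number from compound 3 to compound 4 (0.22 log units; within the scatter). The estimate for compound 4 is 32000 nM, with an expected range of 13000 nM to 75000 nM.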

Compound 4, half-maximal cytotoxic concentration: 13800 nM
Estimate against measurement, compound 4: 2.3-fold (0.37 log units) above, and the stated range covers the measured number.
By their numbers in this assay, from the lowest: compounds 4 and 2 (each within the scatter of the next); then compound 3. At a limit, above all of these: compound 1.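

On the shared core, this position now has a reading of one change alone: in this assay, isopropyl in place of methyl on an oxygen next to a carbonyl group gives a 3.9-fold lower number from compound 3 to compound 4 (0.59 log units; beyond the scatter). The earlier compounds shown here could not show this, since they differ in their cores as well as in their esters. Nothing measured here accounts for the step.

Going by these compounds, a single pair gives no trend, so it remains open how the number responds to other groups on the same oxygen, such as ethyl, n-butyl or cyclopropyl. On these data alone, it is also open whether isopropyl in place of methyl would give a step of similar size on the other cores.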